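Adding a second fluoro to the shared core

The source may report more compounds than this note shows. Statements on the series, on what has been measured and on what is new or still open speak of the compounds shown alone.

Measured so far:
compound 1, `CCC(Nc1nnc(-c2ccc(OC)cc2)o1)[C@H]1CC[C@@H](c2ccnc3ccc(F)cc32)CC1`, 31 nM
compound 2, `C[C@@H](c1nc2ncc(Cl)cc2[nH]1)[C@H]1CC[C@@H](c2ccnc3ccc(F)cc32)CC1`, 36 nM

Both compounds were tested in an assay on tissue (M109 cells) for inhibition of Indoleamine 2,3-dioxygenase 1 (Mus musculus), read by fluorescence, with a stated time of 18 h; a lower number here means a stronger inhibitor, a higher number a weaker inhibitor. Compound 1 gives 31 nM, the lowest of the two numbers, and compound 2 gives 36 nM. The gap between them is within the scatter, so the two compounds cannot be ranked against each other on these data.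

The piece now follows the step from compound 1 to compound 3, `CCC(Nc1nnc(-c2ccc(OC)cc2)o1)[C@H]1CC[C@@H](c2ccnc3c(F)cc(F)cc32)CC1`, which has not yet been measured. The change is fluoro in place of hydrogen on an aromatic carbon. The new fluoro sits on an aromatic carbon of a six-membered aromatic ring of carbon only, part of a fused system of two rings, ortho to a fused ring and meta to the fluoro already present. Within the data shown here, no measured pair shows what such a change does here, so the expectation rests on compound 1 alone. Compound 3 is expected to show a step of a 1.1-fold higher number from compound 1 to compound 3 (0.05 log units; within the scatter), that is, no change beyond the scatter. The estimate for compound 3 is 35 nM, with a range from 14 nM to 85 nM.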

Compound 3, half-maximal inhibitory concentration: 36 nM
The estimate for compound 3 lay 1.0-fold (0.01 log units) below the measured number, within the range that was stated.
By their numbers in this assay, from the lowest: compounds 1, 2 and 3 (each within the scatter of the next).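

In this assay, among these compounds, this is the first pair of compounds that differ in one place, and it isolates fluoro in place of hydrogen on an aromatic carbon of a six-membered aromatic ring of carbon only, ortho to a fused ring and meta to a fluoro group, with a 1.2-fold higher number from compound 1 to compound 3 (0.06 log units; within the scatter). The earlier compounds shown here could say nothing about this carbon, whereas this pair shows that, with the side chain of compound 1 in place, the added fluoro brings no change beyond the scatter. Nothing measured here bears on why the number stays within the scatter.

This single pair leaves open whether the same fluoro would also bring no change beyond the scatter with the side chain of compound 2 in place, as no pair of compounds shown tests it. It also leaves open how this aromatic carbon would respond to a group other than fluoro, such as an amine or a carboxylic acid, since fluoro is the only group shown there apart from hydrogen.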